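The source may hold more compounds than are shown below. What is called first, only, known or untested is meant among the compounds shown, and "the series" means these compounds.

Within the data shown here, in a functional assay on HL-60 cells (Homo sapiens) for antiproliferative activity, read by MTT assay, with a stated time of 72 h (on this read-out higher numbers stand for weaker inhibition and lower numbers for stronger inhibition), two compounds have numbers so far. Compound 1 (`NC1=NC2(CCOCC2)N(OCCCOc2ccccc2)C(N)=N1`) gives 2460 nM and compound 2 (`NC1=NC2(CCSCC2)N(OCCCOc2ccc(Br)cc2)C(N)=N1`) gives 350 nM as the lower of the two numbers. The gap between them lies beyond the usual scatter of repeat measurements, so compound 2 is the stronger inhibitor of this pair.

The next compound to be measured is compound 3 (`NC1=NC2(CCSCC2)N(OCCCOc2ccc(Cl)cc2)C(N)=N1`). It differs from compound 2 in one place (chloro in place of bromo on an aromatic carbon), so 4-bromophenoxy becomes 4-chlorophenoxy. The rest of the molecule stays the same.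

Among the measured compounds shown here, no tested pair differs in only one place, so the data offer no measured step to serve as a guide. The expectation therefore rests on the modest size of the swap and on the value of compound 2 (350 nM) as the starting point. No step beyond the scatter is expected in this assay, in either direction. The estimate amounts to a 1.1-fold higher number from compound 2 to compound 3 (0.04 log units; within the scatter) and so stays small. For compound 3 the estimated value is 380 nM with an expected range from 170 nM to 850 nM in this measurement.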

Compound 3, half-maximal inhibitory concentration: 430 nM
Estimate against measurement, compound 3: 1.1-fold (0.05 log units) below; low and high end bracket the measured number.
By their numbers in this assay, from the lowest: compounds 2 and 3 (each within the scatter of the next); then compound 1.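

In this assay, among these compounds, the change of bromo to chloro on the aromatic ring, at the place para to a large group, provides the first step that can be read at a single position: a 1.2-fold higher number from compound 2 to compound 3 (0.09 log units; within the scatter) stays within the scatter of repeated measurements. On this evidence, 4-bromophenoxy and 4-chlorophenoxy cannot be told apart in this assay when the rest of the molecule stays the same, though this one pair says nothing about other substituents at this place. No supporting data are available to explain why the two compounds read alike.

The compounds shown leave open whether this place tolerates changes of other kinds, such as plain hydrogen, a methoxy group, a nitrile or a carboxylic acid, or whether one of these would produce a step beyond the scatter. Compound 1 differs from compound 2 in more than one place, so the contribution of each difference remains unresolved, including that of the bromo group and that of the atom in the saturated ring.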